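Swapping an amide for a thiophene on the piperidine chain

The source may hold more compounds than are shown below. What is called first, only, known or untested is meant among the compounds shown, and "the series" means these compounds.

Measured so far:
compound 1, `CNC(=O)CN1CCC(c2cc3c(-c4ccc(=O)n(C(C)C)c4)ccnc3[nH]2)CC1`, 1.7 uL/min
compound 2, `COc1cc(F)ccc1-c1ccnc2[nH]c(C3CCN(CC(=O)N(C)C)CC3)cc12`, 4.9 uL/min
compound 3, `COc1cc(C(=O)N2CCCC2)ccc1-c1ccnc2[nH]c(C3CCOCC3)cc12`, 46 uL/min

Three compounds sharing one core have been run in an ADME assay on cells (Hepatocyte, Homo sapiens) for metabolic stability; on this read-out lower numbers stand for slow clearance and higher numbers for fast clearance. Compound 1 gives 1.7 uL/min, the lowest number of the three. Compound 2 gives 4.9 uL/min, a number beyond the scatter above that of compound 1, and compound 3 gives 46 uL/min, well beyond the scatter above it. No pair among these three differs in only one place, so none of the gaps can be tied to a single structural change.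

The next compound, compound 4, `CC(C)n1cc(-c2ccnc3[nH]c(C4CCN(Cc5cccs5)CC4)cc23)ccc1=O`, has not yet been measured in this assay. It differs from compound 1 in one place: thiophen-2-yl in place of methylcarbamoyl on a saturated chain carbon bound to an amine nitrogen in a ring. The methylcarbamoyl group carried the only hydrogen-bond donor on that chain; the thiophen-2-yl that takes its place brings an aromatic ring and no donor.

Among the measured compounds shown here, no measured pair shows this change, so the expectation rests only on the values above. The step from compound 1 to compound 4 in this assay is expected to be a 7.1-fold higher number from compound 1 to compound 4 (0.85 log units; beyond the scatter), an upward move beyond the scatter. Compound 4 is estimated at 12 uL/min, with a likely range from 4 uL/min to 35 uL/min.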

Compound 4, intrinsic clearance in a liver preparation (reported as CLH), per the amount of preparation that the assay uses: 5.8 uL/min
Beside the measured number, compound 4's estimate is 2.1-fold (0.32 log units) above it, and the stated range covers the measured number.
By their numbers in this assay, from the lowest: compound 1; then compounds 2 and 4 (each within the scatter of the next); then compound 3.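

In this assay, among the compounds shown here, this is the first pair in the set that differs in only one place, so a gap can now be tied to a single change: thiophen-2-yl in place of methylcarbamoyl on a saturated chain carbon bound to an amine nitrogen in a ring gives a 3.4-fold higher number from compound 1 to compound 4 (0.53 log units; beyond the scatter) in what is a modest step. The read-out at this position therefore does respond to the group placed there, yet the step is one pair wide, and it cannot separate the loss of the methylcarbamoyl group, with its hydrogen-bond donor, from the arrival of an aromatic ring. Nothing available here accounts for the size or direction of this step.

Going by these compounds, it remains open whether the number follows the group that leaves or the group that enters, and a phenyl ring, a carboxylic acid, a simple amine or a longer chain at the same place would help to tell these apart. On these data alone, it is also open whether the same swap would give a step of similar size when the rest of the molecule is different.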